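The compounds below may be only part of what the source reports. "The series", "measured", "known", "first", "only" and "open" are said of these compounds alone.

Compound 2 `Cc1cc(C)cc(C(=O)Nc2cccc(/C=C/C(=O)c3nc4ccccc4[nH]3)c2)c1` belongs to a pair of compounds that share one core and differ only in the group attached to the amide nitrogen. In a functional assay on MCF7 cells (Homo sapiens) for antiproliferative activity, read by MTT assay, with a stated time of 48 h (on this read-out lower numbers stand for stronger inhibition and higher numbers for weaker inhibition), compound 2 gives 24600 nM, the highest of the two numbers seen so far. Compound 1 `O=C(Nc1cccc(/C=C/C(=O)c2nc3ccccc3[nH]2)c1)c1cccc(Cl)c1` gives 7840 nM in this assay, and the step of a 3.1-fold higher number from compound 1 to compound 2 (0.50 log units; beyond the scatter) shows how much the number rises with that change of aromatic group. Compound 3 `Cc1cccc(S(=O)(=O)Nc2cccc(/C=C/C(=O)c3nc4ccccc4[nH]3)c2)c1` has not yet been measured. Its difference from compound 2 is (3-methylphenyl)sulfonyl in place of (3,5-dimethylphenyl)carbonyl on a nitrogen on an aromatic ring. Within the data shown here, no measured step bears directly on this change: the one known step, a 3.1-fold higher number from compound 1 to compound 2 (0.50 log units; beyond the scatter), alters only the aromatic ring on the carbonyl, while here the carbonyl itself is replaced by a sulfonyl. Among the measured compounds shown here, with no comparable step to lean on, no change beyond the scatter is expected, and compound 3 is estimated at 15000 nM, within a range from 4000 nM to 60000 nM, which corresponds to an expected step of a 1.6-fold lower number from compound 2 to compound 3 (0.21 log units; within the scatter).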

Compound 3, half-maximal inhibitory concentration: 886 nM
Compound 3: middle estimate off by 17-fold (1.23 log units), on the high side; the measured number lies below the stated range.
By their numbers in this assay, from the lowest: compound 3; then compound 1; then compound 2.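

In this assay the earlier pair showed only what changing the aromatic ring on the carbonyl does. Putting (3-methylphenyl)sulfonyl on this nitrogen moves the number much further, with a 28-fold lower number from compound 2 to compound 3 (1.44 log units; beyond the scatter) and an 8.8-fold lower number from compound 1 to compound 3 (0.95 log units; beyond the scatter). Both steps run the same way, so compound 3 stands lowest against either amide, and since (3,5-dimethylphenyl)carbonyl and (3-methylphenyl)sulfonyl both hold 10 heavy atoms, that count does not separate compound 2 from compound 3.

Nothing measured here tells why the number falls. Each step also changes the substituents on the outer ring along with the carbonyl-to-sulfonyl swap. These data do not separate the two changes, and they do not show whether a methoxy group or an amine on that ring would keep the number this low.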